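Swapping the 4-hydroxycyclohexyl urea substituent for an aromatic ring

The source may report more compounds than this note shows. Statements on the series, on what has been measured and on what is new or still open speak of the compounds shown alone.

Three ureas built on one shared core were measured in a functional assay on Shh Light II cells (Mus musculus) for inhibition, read by a luciferase reporter; a lower number here means a stronger inhibitor, a higher number a weaker inhibitor. Compound 2 `O=C(NC1CCC(O)CC1)N1CCC(c2nc(-c3ccc4ccccc4n3)no2)CC1` gives 2700 nM, the highest of the three numbers. Compound 1 `O=C(NC1CCS(=O)(=O)CC1)N1CCC(c2nc(-c3ccc4ccccc4n3)no2)CC1` gives 360 nM, and compound 3 `COc1ccccc1NC(=O)N1CCC(c2nc(-c3ccc4ccccc4n3)no2)CC1` gives 410 nM. The steps of a 7.5-fold higher number from compound 1 to compound 2 (0.88 log units; beyond the scatter) and a 6.6-fold lower number from compound 2 to compound 3 (0.82 log units; beyond the scatter) both set compound 2 apart from its neighbours. Compound 4 `Cc1noc(C)c1NC(=O)N1CCC(c2nc(-c3ccc4ccccc4n3)no2)CC1` carries the change (3,5-dimethyl-1,2-oxazol-4-yl in place of 4-hydroxycyclohexyl on an amide-type nitrogen). Going by the values given here, of the measured steps, the one from compound 2 to compound 3 bears most closely on this change: there too a ring bearing no hydrogen-bond donor took the place of the 4-hydroxycyclohexyl group, and compound 1 also lacks a donor. A downward step is therefore expected, a 5.4-fold lower number from compound 2 to compound 4 (0.73 log units; beyond the scatter). Compound 4 is estimated at 500 nM, between 200 nM and 1500 nM.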

Compound 4, half-maximal inhibitory concentration: 3000 nM
For compound 4 the middle estimate is 6.0-fold (0.78 log units) below the measured one; measured number above the stated range.
By their numbers in this assay, from the lowest: compounds 1 and 3 (each within the scatter of the next); then compounds 2 and 4 (each within the scatter of the next).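

Losing the hydrogen-bond donor of the 4-hydroxycyclohexyl group is not enough on its own at this amide-type nitrogen, since this assay gives a 1.1-fold higher number from compound 2 to compound 4 (0.05 log units; within the scatter). The link between lacking a donor and a lower number, suggested by compound 1 and compound 3, therefore fails with compound 4, as shown by a 7.3-fold higher number from compound 3 to compound 4 (0.86 log units; beyond the scatter) and by an 8.3-fold higher number from compound 1 to compound 4 (0.92 log units; beyond the scatter). Nothing measured here accounts for the gap between the 3,5-dimethyl-1,2-oxazol-4-yl and 2-methoxyphenyl groups. The compounds leave open whether an unsubstituted phenyl group, or an amine in place of the hydroxyl on the cyclohexyl ring, would track with compound 3 or with compound 4.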